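This account rests on a few compounds, and the source may have more. Where it says the series, first, only, none or still open, it means among the compounds named here.

Compound 1, `COc1ccc(Cn2cnc3c(N(C)c4ccc(OC)cc4)ncnc32)cc1`: > 100000 nM
Compound 2, `COc1ccc(Cn2cnc3c(N(C)c4ccc(OC)cc4)nc(Cl)nc32)cc1`: > 100000 nM
Compound 3, `COc1cc(Cn2cnc3c(Cl)ncnc32)cc(OC)c1`: > 100000 nM

In a functional assay on K562 cells (Homo sapiens) for antiproliferative activity, read by MTT assay, with a stated time of 48 h (a higher number here means a weaker inhibitor of growth, a lower number a stronger inhibitor of growth), compound 1 gives > 100000 nM, which is a limit of the assay and not a number. Compound 2 gives > 100000 nM, again a limit. Compound 3 gives > 100000 nM, also a limit. The change from compound 1 to compound 2 is chloro in place of hydrogen on an aromatic carbon, and the step that the two limits leave unreadable from compound 1 to compound 2 stays unreadable because of the limit of > 100000 nM in this assay, at which 3 of the 3 values shown sit. Compound 4, `COc1cc(Cn2cnc3c(Cl)nc(Cl)nc32)cc(OC)c1`, has not yet been measured in this assay. It differs from compound 3 by chloro in place of hydrogen on an aromatic carbon, the same kind of change as that from compound 1 to compound 2, though the surroundings differ: in compound 3 the place is meta to a chloro group, whereas in compound 1 it is meta to a large group. How the core of compound 1 and the core of compound 3 differ is not broken down here. For compound 4 the step that the limit leaves unreadable from compound 3 to compound 4 is expected to be small, since compound 3 gives > 100000 nM and the same kind of change left compound 2 at a limit as well. Compound 4 is therefore estimated at 150000 nM, between 30000 nM and 600000 nM, most likely reported again only as a limit.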

Compound 4, concentration for 50% growth inhibition: 4600 nM
Compound 4: the middle estimate sits 33-fold (1.51 log units) above what was measured; measured number below the stated range.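

In this assay, chloro in place of hydrogen on an aromatic carbon between two ring nitrogen atoms gives an at least 21-fold lower number from compound 3 to compound 4 (1.33 log units; beyond the scatter). As far as these compounds go, the same kind of change on the core of compound 1 cannot be read, because both compound 1 and compound 2 sit at a limit: the limit of > 100000 nM in this assay, at which 3 of the 4 values shown sit. The series therefore shows that this change can go with a large step on the core of compound 3, but it does not show that the step carries over to the core of compound 1, where the size of any step remains unknown and compound 2 offers no measured number to set against compound 4.

The compounds shown leave open whether another group at the same place, such as bromo, a nitrile or an amine, would match chloro on the core of compound 3. They also leave open what happens in compound 4 when its other chloro group gives way to an amine or a longer chain.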